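Removing the Phenyl Methyl While Keeping the Methylpiperidine

A few compounds are considered here, and "the series" means these few. Any claim that something is new, unique, unknown or untested is made for them only; others in the source may bear on it.

Of the compounds shown here, two have been measured in a functional assay on A549 cells (Homo sapiens) for cytotoxicity, read by MTT assay, with a stated time of 72 h; on this read-out lower numbers stand for stronger inhibition and higher numbers for weaker inhibition. Compound 1 `COc1cc2c(Oc3ccc(NC(=O)c4nnn(-c5ccccc5)c4C)cc3F)ccnc2cc1OCCCN1CCCC1` gives 90 nM. Compound 2 `COc1cc2c(Oc3ccc(NC(=O)c4nnn(-c5ccccc5C)c4C)cc3F)ccnc2cc1OCCCN1CCC(C)CC1` gives 360 nM, the higher of the two numbers; the gap between compound 1 and compound 2 lies beyond the usual scatter of repeated measurements. The two compounds differ in two places at once, so their values alone cannot say which of the two changes matters.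

Compound 3 `COc1cc2c(Oc3ccc(NC(=O)c4nnn(-c5ccccc5)c4C)cc3F)ccnc2cc1OCCCN1CCC(C)CC1` has not yet been measured. It differs from compound 2 in one place only: hydrogen in place of methyl on an aromatic carbon. Compound 3 therefore carries the plain phenyl of compound 1 together with the longer chain end of compound 2.

Among the compounds with values here, no measured pair isolates this single change, so the expectation rests on the two values shown. Because compound 1, which also carries the plain phenyl, gives 90 nM, the number for compound 3 is expected to move downward, and the step is estimated as a 2.4-fold lower number from compound 2 to compound 3 (0.38 log units; beyond the scatter), beyond the scatter. Compound 3 is accordingly expected to give about 150 nM, with a plausible range from 60 nM to 450 nM.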

Compound 3, half-maximal inhibitory concentration: 110 nM
Compound 3: middle estimate off by 1.4-fold (0.13 log units), on the high side, within the range that was stated.
By their numbers in this assay, from the lowest: compounds 1 and 3 (each within the scatter of the next); then compound 2.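

In this assay, the change from 2-methylphenyl to phenyl, with the 4-methylpiperidin-1-yl chain end held fixed, gives a 3.3-fold lower number from compound 2 to compound 3 (0.51 log units; beyond the scatter); the methyl on this aromatic carbon, ortho to a large group, therefore weakens inhibition on its own. With the plain phenyl held fixed, the change at the chain end from pyrrolidin-1-yl to 4-methylpiperidin-1-yl gives a 1.2-fold higher number from compound 1 to compound 3 (0.09 log units; within the scatter), so the two chain ends cannot be told apart in this assay, and of the two single changes, only the loss of the methyl gives a step beyond the scatter. Nothing in the data at hand gives a reason for the methyl step.

On these data alone, whether the methyl has the same effect with pyrrolidin-1-yl at the chain end remains open, since the methyl step is seen here with only one chain end. Also open, as far as these compounds go, is how other groups on that aromatic carbon, such as a fluorine, a chlorine or a methoxy group, would compare with hydrogen and methyl.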